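Three Limits and an Estimate for a Fourth Compound

A few compounds are considered here, and "the series" means these few. Any claim that something is new, unique, unknown or untested is made for them only; others in the source may bear on it.

Compound 1 `CNC(=O)c1cc(Oc2ccc3nc(Nc4cccc(C(C)(C)C)c4)cnc3c2)ccn1`, compound 2 `CCc1ccccc1Nc1ncc2cc(Oc3ccnc(C(=O)NC)c3)ccc2n1` and compound 3 `CNC(=O)c1cc(Oc2ccc3nc(Nc4ccccc4Oc4ccccc4)ncc3c2)ccn1` share one core and differ only in the aryl group carried on the amine nitrogen. In an ADME assay on Caco-2 cells (Homo sapiens) for permeability, in the apical to basolateral direction (a lower number here means that the compound crosses the layer more slowly, a higher number that the compound crosses the layer faster), compound 1 gives only a limit, < 1 10^-6 cm/s. In this assay compound 2 likewise gives only a limit, < 1 10^-6 cm/s. In this assay compound 3 also gives only a limit, < 1 10^-6 cm/s. All three values shown therefore sit at the limit of < 1 10^-6 cm/s in this assay, at which 3 of the 3 values shown sit, and compound 2 stands at that limit without a number of its own. Among the measured compounds shown here, the single step between measured compounds, a step that the two limits leave unreadable from compound 2 to compound 3, accordingly cannot be read in size or direction. The unmeasured compound 4 `CNC(=O)c1cc(Oc2ccc3nc(Nc4ccc(C(F)(F)F)cc4)ncc3c2)ccn1` differs from compound 2 in one place: 4-(trifluoromethyl)phenyl in place of 2-ethylphenyl on a nitrogen on an aromatic ring. For the measured compounds named here, no measured step follows this particular change, and the one step that is known is itself unreadable; the only guidance is that every compound measured so far rests at the limit. For compound 4 the value in this assay is therefore expected to remain near that limit as well. The step that this expectation implies is a step that the limit leaves unreadable from compound 2 to compound 4, estimated as small. The estimate for compound 4 is 0.6 10^-6 cm/s, expected to lie between 0.1 10^-6 cm/s and 2.5 10^-6 cm/s.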

Compound 4, apparent permeability: < 1 10^-6 cm/s
Compound 4 ended at the assay's limit (the forecaster's own chance of this, stated with the estimate: 75%); the middle value does not contradict the limit.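

Among the compounds shown here, compound 4, like compound 2, gives only a limit in this assay, so no step between the two can be read, in size or in direction. The compounds shown leave open whether changing the aryl group on the amine nitrogen alters the value at all, for they show only one position: the limit of < 1 10^-6 cm/s in this assay, at which 4 of the 4 values shown sit.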